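Working notes: methoxy for chloro in compound 3

The source may report more compounds than this note shows. Statements on the series, on what has been measured and on what is new or still open speak of the compounds shown alone.

Values in a functional assay on PC-3 cells (Homo sapiens) for inhibition, read by sulforhodamine B assay, with a stated time of 48 h (a higher number here means a weaker inhibitor of growth, a lower number a stronger inhibitor of growth), are as follows.
- compound 1 `CCOC(=O)c1nn(-c2ccccc2)c(-c2ccc(Cl)cc2)c1CNC(C)(C)C` gives 28600 nM; > 559000 nM (2 entries)
- compound 2 `CCOC(=O)c1nn(-c2ccccc2)c(-c2ccccc2)c1CNC(C)(C)C` gives 39900 nM; 91700 nM (2 entries)
- compound 3 `CC(C)(C)NCc1c(C(=O)O)nn(-c2ccccc2)c1-c1ccc(Cl)cc1` gives 145000 nM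

One of the entries of compound 1 is a limit of the assay. Compound 3 rests on a single entry, 145000 nM, and that number falls inside the span of the entries of compound 1 (the several entries of compound 1 in this assay, 28600 nM; > 559000 nM (2 entries)). Repeat entries also differ for compound 2 (the several entries of compound 2 in this assay, 39900 nM; 91700 nM (2 entries)). Compound 4 `COc1ccc(-c2c(CNC(C)(C)C)c(C(=O)O)nn2-c2ccccc2)cc1` is not yet measured and has methoxy in place of chloro on an aromatic carbon. Among the compounds with values here, no measured pair isolates this change, so no step beyond the scatter is expected in this assay. The expected step is a 1.1-fold lower number from compound 3 to compound 4 (0.05 log units; within the scatter). The estimate for compound 4 is 130000 nM, with an expected range from 45000 nM to 400000 nM.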

Compound 4, concentration for 50% growth inhibition: > 659000 nM
Compound 4 was reported as a limit (the forecaster's own chance of this, stated with the estimate: 20%); middle value at least 5.0-fold (0.70 log units) from the limit.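

In this assay, within the data shown here, the 4-chlorophenyl to 4-methoxyphenyl change gives the first step that can be read at this position, para to a large group: an at least 4.5-fold higher number from compound 3 to compound 4 (0.65 log units; beyond the scatter). Compound 4 gives > 659000 nM, which is a limit of the assay. Compound 3 rests on a single entry, and repeat entries in this series spread widely, so the step stays tentative: the several entries of compound 1 in this assay, 28600 nM; > 559000 nM (2 entries)

The compounds shown leave open how a methyl, a hydroxyl or an amine would read at this position. Going by these compounds, whether the same change carries over to compound 1 also remains open.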